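Shrinking the benzylic amine of compound 3: a dimethylamino analogue

The compounds below may be only part of what the source reports. "The series", "measured", "known", "first", "only" and "open" are said of these compounds alone.

Compound 1 `CCC[C@@H](CO)Nc1nc(N)nc(C)c1Cc1ccc(CNCCO)cc1OC` gives 5370 nM in an assay on HEK293 cells for agonist activity at Toll-like receptor 8 (Homo sapiens); a higher number here means that more compound is needed for the effect, a lower number that less compound is needed.
Compound 2 `CCC[C@@H](CO)Nc1nc(N)nc(C)c1Cc1ccc(CNC)cc1OC` gives 2140 nM in this assay.
Compound 3 `CCC[C@@H](CO)Nc1nc(N)nc(C)c1Cc1ccc(CNC2CN(C)C2)cc1OC` gives 6170 nM in this assay.

Compound 3 has the highest of the three numbers, though its gap to compound 1 lies within the scatter. Compound 4 `CCC[C@@H](CO)Nc1nc(N)nc(C)c1Cc1ccc(CN(C)C)cc1OC` carries the change (dimethylamino in place of (1-methylazetidin-3-yl)amino on a saturated chain carbon bound to an aromatic carbon). For the measured compounds named here, two measured steps bear on this: a 2.9-fold higher number from compound 2 to compound 3 (0.46 log units; beyond the scatter), so the reverse direction, back to a small amine, should lower the number; and a 2.5-fold lower number from compound 1 to compound 2 (0.40 log units; beyond the scatter) also points toward smaller groups at this site needing less compound. Compound 4 resembles compound 2 with one added methyl, so its number is expected to fall near that of compound 2, an expected step of a 2.5-fold lower number from compound 3 to compound 4 (0.39 log units; beyond the scatter). For compound 4 the estimate in this assay is 2500 nM, ranging from 1000 nM to 6000 nM.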

Compound 4, half-maximal effective concentration: 490 nM
Estimate against measurement, compound 4: 5.1-fold (0.71 log units) above, outside the stated range (below it).
By their numbers in this assay, from the lowest: compound 4; then compound 2; then compounds 1 and 3 (each within the scatter of the next).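

Methyl in place of hydrogen on the amine nitrogen makes the group larger, yet the result is a 4.4-fold lower number from compound 2 to compound 4 (0.64 log units; beyond the scatter) and so smaller size alone does not account for this position. Dimethylamino, the only group here with no hydrogen-bond donor, stands well apart from the larger groups through a 13-fold lower number from compound 3 to compound 4 (1.10 log units; beyond the scatter) and an 11-fold lower number from compound 1 to compound 4 (1.04 log units; beyond the scatter) as well. No measurement shown accounts for these differences.

These compounds cannot separate the loss of the amine hydrogen from the added methyl itself. Diethylamino or pyrrolidine at this site would show whether other amines without that hydrogen give similarly low numbers.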